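Ethyl versus methyl esters on two thienyl-amine cores

The source may hold more compounds than are shown below. What is called first, only, known or untested is meant among the compounds shown, and "the series" means these compounds.

The series pairs a trimethoxyphenyl amine with a fused thiophene ester and varies both the core and the ester chain. Compound 3 `COC(=O)c1sc2ccccc2c1Nc1cc(OC)c(OC)c(OC)c1` is measured in a functional assay on MCF7 cells (Homo sapiens) for cytotoxicity, read by MTT assay, with a stated time of 72 h (on this read-out lower numbers stand for stronger inhibition and higher numbers for weaker inhibition), and gives 795 nM. Compound 1 `CCOC(=O)c1sc2ccccc2c1Nc1cc(OC)c(OC)c(OC)c1` shares its core and differs by methyl in place of hydrogen on a saturated chain carbon bound to an oxygen next to a carbonyl group; in this assay compound 1 gives 6390 nM. This change gives an 8.0-fold higher number from compound 3 to compound 1 (0.91 log units; beyond the scatter).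

Compound 2 `COC(=O)c1sc2ncccc2c1Nc1cc(OC)c(OC)c(OC)c1` carries a different core; how its core differs from that of compound 3 is not broken down here. In this assay compound 2 gives 2640 nM, a number between those of compound 1 and compound 3.

Compound 4 `CCOC(=O)c1sc2ncccc2c1Nc1cc(OC)c(OC)c(OC)c1` is not yet measured. It differs from compound 2 by methyl in place of hydrogen on a saturated chain carbon bound to an oxygen next to a carbonyl group, which is the same change as that from compound 3 to compound 1, made at the same place on the other core. Within the data shown here, only one measured example of this change exists, so the step from compound 2 to compound 4 in this assay is expected to be of similar size, a 6.1-fold higher number from compound 2 to compound 4 (0.78 log units; beyond the scatter), resting on the step seen from compound 3 to compound 1 of an 8.0-fold higher number from compound 3 to compound 1 (0.91 log units; beyond the scatter). Going by these compounds, the transfer from one core to the other is untested, so the range is kept wide. Compound 4 is therefore estimated at 16000 nM, with the plausible span running from 5000 nM to 50000 nM.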

Compound 4, half-maximal inhibitory concentration: 5280 nM
Compound 4: the middle estimate sits 3.0-fold (0.48 log units) above what was measured, and the stated range covers the measured number.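

In this assay, the change from methoxycarbonyl to ethoxycarbonyl on the core of compound 2 gives a 2.0-fold higher number from compound 2 to compound 4 (0.30 log units; within the scatter), so on this core the read-out does not separate the two esters. The size of the step therefore does not carry over from the core of compound 3, where the ethyl ester clearly reads higher, to the core of compound 2: the same change on two cores in this assay, an 8.0-fold higher number (0.91 log units; beyond the scatter) from compound 3 to compound 1 and a 2.0-fold higher number (0.30 log units; within the scatter) from compound 2 to compound 4, 4.0-fold (0.60 log units) apart, beyond the scatter of two such steps. This shows that the effect of the change depends on the core within these four compounds, but with a single pair on each core it does not show why the cores differ, nor does it give a rule for any further core.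

Going by these compounds, it remains open whether a longer chain on the ester, such as propyl or butyl, would continue the steep rise on the core of compound 3 while staying flat on the core of compound 2. Replacing the ester with a carboxylic acid or an amide on both cores would test whether the dependence on the core is specific to the ester chain or extends to other groups at that place.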